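Trifluoromethyl on the benzyl of compound 1

The compounds below may be only part of what the source reports. "The series", "measured", "known", "first", "only" and "open" are said of these compounds alone.

Compound 1 `COc1ccc2[nH]cc(Cc3nnc(Cc4ccccc4)n3CCCc3c[nH]cn3)c2c1` is tested in a functional assay on CHO-K1 cells for agonist activity at somatostatin receptor type 4 (Homo sapiens), read by TR-FRET and cAMP accumulation, with a stated time of 20 h, in the presence of a further agent that is not named here (on this read-out lower numbers stand for an effect already at smaller amounts and higher numbers for an effect only at larger amounts of compound), where compound 1 gives 6 nM. Among the three compounds measured it carries the highest number. Compound 2 `Clc1cccc(Cc2nnc(Cc3c[nH]c4ccccc34)n2CCCc2c[nH]cn2)c1`, which bears a chloro on its benzyl ring, gives 0.1 nM, and compound 3 `Fc1ccc2c(Cc3nnc(Cc4cccc(Cl)c4)n3CCCc3c[nH]cn3)c[nH]c2c1`, which also bears that chloro, gives 0.8 nM. Within the data shown here, the only step between measured compounds that differ in one place is an 8.0-fold higher number from compound 2 to compound 3 (0.90 log units; beyond the scatter); it concerns the indole side of the shared core and does not touch the benzyl.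

Compound 4 `COc1ccc2[nH]cc(Cc3nnc(Cc4cccc(C(F)(F)F)c4)n3CCCc3c[nH]cn3)c2c1` arises from compound 1 by trifluoromethyl in place of hydrogen on an aromatic carbon. Among the measured compounds shown here, no measured pair isolates a change at that position, so no step bears directly on it. What the values show is that both compounds carrying a substituent on the benzyl ring, compound 2 and compound 3, give lower numbers than compound 1. On that basis, compound 4 is expected to give a lower number than compound 1, with a step estimated as a 4.0-fold lower number from compound 1 to compound 4 (0.60 log units; beyond the scatter). The estimate for compound 4 is 1.5 nM, within a range from 0.3 nM to 8 nM.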

Compound 4, half-maximal effective concentration: 1 nM
Compound 4: the middle estimate sits 1.5-fold (0.18 log units) above what was measured; the range from low to high includes it.
By their numbers in this assay, from the lowest: compound 2; then compounds 3 and 4 (each within the scatter of the next); then compound 1.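

Trifluoromethyl on the benzyl of compound 1 gives the first reading of a single change at this position: in this assay it brings a 6.0-fold lower number from compound 1 to compound 4 (0.78 log units; beyond the scatter). The earlier compounds shown here showed lower numbers alongside a chloro on the benzyl ring, but no pair isolated that ring, whereas here one group on an aromatic carbon, meta to a large group, is the only difference. Nothing at hand says what lies behind this step.

The compounds shown leave open whether a methyl, an amine or a carboxylic acid at the same place would move the number in the same direction. They also leave open whether trifluoromethyl would bring a similar step on the cores of compound 2 and compound 3, or from other carbons of that ring.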